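Replacing carbamoyl on compound 2: what the limits allow

This account rests on a few compounds, and the source may have more. Where it says the series, first, only, none or still open, it means among the compounds named here.

In an ADME assay on MDBK cells (Bos taurus) for cytotoxicity, read by MTT assay, with a stated time of 96 h (on this read-out lower numbers stand for higher toxicity in this test and higher numbers for lower toxicity in this test), compound 1 `C/C(=N\NC(N)=O)c1ccc2[nH]c(-c3ccccc3)nc2c1` gives > 100000 nM, which is a limit. Compound 2 `C/C(=N\NC(N)=O)c1ccc2[nH]c(-c3ccc(C(F)(F)F)cc3)nc2c1` gives > 100000 nM, also a limit, so it stands at the limit of > 100000 nM in this assay, at which 2 of the 3 values shown sit. Compound 3 `COc1ccc(-c2nc3cc(/C(C)=N/NC(N)=O)ccc3[nH]2)cc1` gives a true number, 25000 nM. Of the steps among them, one is unreadable, a step that the two limits leave unreadable from compound 1 to compound 2, while another is an at least 4.0-fold lower number from compound 1 to compound 3 (0.60 log units; beyond the scatter). Compound 4 `C/C(=N\NC(N)=S)c1ccc2[nH]c(-c3ccc(C(F)(F)F)cc3)nc2c1` differs from compound 2 on an amine nitrogen: a group of 3 heavy atoms (1 carbon, 1 nitrogen, 1 sulfur; no ring) in place of a group of 3 heavy atoms (1 carbon, 1 nitrogen, 1 oxygen; no ring), on an amine nitrogen. Among the measured compounds shown here, no measured step touches that group, so the only guide is the size of a single change at another place. Going by compound 3, with an at least 4.0-fold lower number from compound 2 to compound 3 (0.60 log units; beyond the scatter), a modest drop is expected. The expected change is an at least 3.3-fold lower number from compound 2 to compound 4 (0.52 log units; beyond the scatter). Compound 4 is estimated at 30000 nM, with an expected range of 8000 nM to 100000 nM.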

Compound 4, half-maximal cytotoxic concentration: 5000 nM
Estimate against measurement, compound 4: 6.0-fold (0.78 log units) above; the whole stated range lies above it.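

In this assay, among the compounds shown here, the earlier steps all concerned an aromatic carbon, and this is the first to show that the group on the amine nitrogen also matters. With sulfur in place of oxygen and the count of heavy atoms unchanged, the change gives an at least 20-fold lower number from compound 2 to compound 4 (1.30 log units; beyond the scatter). Compound 2 stands at a limit, not a true number: the limit of > 100000 nM in this assay, at which 2 of the 4 values shown sit.

From the compounds shown here alone, whether the same exchange lowers the number when hydrogen or methoxy replaces trifluoromethyl stays open. So does the outcome with an acetyl group or a longer chain on that amine nitrogen.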